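This account rests on a few compounds, and the source may have more. Where it says the series, first, only, none or still open, it means among the compounds named here.

Measured values in an ADME assay on BJ cells (Homo sapiens) for cytotoxicity, with a stated time of 72 h (a lower number here means that less compound is needed, a higher number that more compound is needed for the effect), are:

compound 1 `Cc1cc(NC(=O)Nc2ccc(Cl)c(Cl)c2)c2ccccc2n1` gives 23000 nM
compound 2 `CCc1ccc(NC(=O)Nc2cc(C)nc3ccccc23)cc1` gives > 25000 nM
compound 3 `Cc1cc(NC(=O)Nc2ccccc2C(C)(C)C)c2ccccc2n1` gives 22000 nM

Compound 2, the starting point here, stands at > 25000 nM and this is a limit of the assay, not a number. It gives no exact position, only the edge of what the test reported.

The next compound to be tested is compound 4 `COC(=O)c1ccc(NC(=O)Nc2cc(C)nc3ccccc23)cc1` in which methoxycarbonyl replaces ethyl on an aromatic carbon, para to a large group methoxycarbonyl in place of ethyl on an aromatic carbon and nothing else changes.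

Within the data shown here, no two measured compounds differ in just one place, so no step can be read directly from the data. Compound 1 at 23000 nM and compound 3 at 22000 nM lie within the usual scatter of each other although their structures differ. On that basis, a step no larger than the scatter is expected in this assay and neither direction is favoured. The estimated step that the limit leaves unreadable from compound 2 to compound 4 is therefore small. Another limit instead of a number would be no surprise.

For compound 4 the estimated value is 26000 nM with an expected range from 13000 nM to 50000 nM and the measurement is still to come.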

Compound 4, half-maximal effective concentration: 21000 nM
Compound 4: the middle estimate sits 1.2-fold (0.09 log units) above what was measured; measured number inside the range.
By their numbers in this assay, from the lowest: compounds 4, 3 and 1 (each within the scatter of the next). At a limit, above all of these: compound 2.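

Among these compounds, replacing ethyl with methoxycarbonyl on an aromatic carbon, para to a large group, gives the first step that can be read at this position in this assay: an at least 1.1-fold lower number from compound 2 to compound 4 (0.07 log units; that floor lies within the scatter). From the compounds shown here alone, the true size of that step stays unknown because compound 2 is fixed only by a limit of the assay, not by a number: the limit of > 25000 nM in this assay, at which 1 of the 4 values shown sits. Compound 4 gives 21000 nM, so this position now carries a real number. The floor of the step lies within the usual scatter, however, and the change, which brings in two hydrogen-bond acceptors where ethyl has none, cannot be said to have moved the result.

Going by these compounds, whether an amine or a carboxylic acid at this same place would give a number clearly apart from that of compound 4 remains open. Also open, on these data alone, is whether a longer chain in place of ethyl would stay at the limit seen for compound 2 or give a number, and a single step at one position cannot show how far this change carries to other parts of the molecule.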